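From compound 2 to the carboxy compound 3

The source may report more compounds than this note shows. Statements on the series, on what has been measured and on what is new or still open speak of the compounds shown alone.

Measured in an ADME assay on microsomes from liver (Mus musculus) for metabolic stability, read by LC-MS, using NADPH, with a stated time of 30 min, tested at 0.1 uM, in the presence of a further agent that is not named here; a lower number here means that less of the compound is left, a higher number that more of the compound is left:
- compound 1 `Nc1ncc(-c2ccc(C(=O)N3CC(O)C3)cc2)nc1-c1ccc(C(F)(F)F)cc1`: > 90%
- compound 2 `Nc1ncc(-c2ccc(C(=O)N3CCC(O)C3)cc2)nc1-c1ccc(C(F)(F)F)cc1`: > 90%

Compound 2 stands at > 90%, which is a limit of the assay and not a number. Compound 1 also gives only a limit. The evidence on the series is therefore thin: the limit of > 90% in this assay, at which 2 of the 2 values shown sit.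

Compound 3 `Nc1ncc(-c2ccc(C(=O)O)cc2)nc1-c1ccc(C(F)(F)F)cc1` has not yet been measured in this assay. It carries hydroxy in place of 3-hydroxypyrrolidin-1-yl on a carbonyl carbon. Cut one bond further out, (3-hydroxypyrrolidin-1-yl)carbonyl gives way to carboxy.

Within the data shown here, the only measured step is a step that the two limits leave unreadable from compound 1 to compound 2. Among the measured compounds shown here, it exchanges one hydroxylated ring on the carbonyl carbon for another, and no measured step removes such a ring altogether. It bears on the present change only loosely, and it gives no size to carry over. No step beyond the usual scatter is expected in either direction, though this is a weakly supported expectation. The estimated change is a step that the limit leaves unreadable from compound 2 to compound 3. For compound 3 the estimated value is 92%, with an expected range from 78% to 100%.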

Compound 3, percent of the compound remaining: > 90%
Compound 3: a limit, no number (the forecaster's own chance of this, stated with the estimate: 55%); the middle value does not contradict the limit.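

Compound 3, like compound 1 and compound 2, gives only a limit of the assay in this assay, so no step among these three compounds can be read: the limit of > 90% in this assay, at which 3 of the 3 values shown sit.

The compounds shown leave open how far these three compounds differ in this assay and whether any change on the carbonyl carbon gives a readable number.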